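Triazolylmethyl spiro series: varying the aryl group on the triazole

A few compounds are considered here, and "the series" means these few. Any claim that something is new, unique, unknown or untested is made for them only; others in the source may bear on it.

Compound 1 `N#CC1=C(N)Oc2c(c3nc4ccccc4nc3c3ccccc23)C12C(=O)N(Cc1cnnn1-c1ccc([N+](=O)[O-])cc1)c1ccccc12` — in a functional assay on HCT-116 cells (Homo sapiens) for antiproliferative activity, read by MTT assay, with a stated time of 48 h (on this read-out higher numbers stand for weaker inhibition and lower numbers for stronger inhibition), compound 1 gives the limit > 50000 nM.
Compound 2 `CC(=O)Nc1ccc(-n2nncc2CN2C(=O)C3(C(C#N)=C(N)Oc4c3c3nc5ccccc5nc3c3ccccc43)c3ccccc32)cc1` — in this assay compound 2 gives the limit > 50000 nM.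
Compound 3 `N#CC1=C(N)Oc2c(c3nc4ccccc4nc3c3ccccc23)C12C(=O)N(Cc1cnnn1-c1cccc(S(N)(=O)=O)c1)c1ccccc12` — in this assay compound 3 gives 11300 nM.

Within the data shown here, compound 3 holds the only number in the set; the other two values are limits (the limit of > 50000 nM in this assay, at which 2 of the 3 values shown sit). The steps of an at least 4.4-fold lower number from compound 1 to compound 3 (0.64 log units; beyond the scatter) and an at least 4.4-fold lower number from compound 2 to compound 3 (0.64 log units; beyond the scatter) both mark the arrival of the 3-sulfamoylphenyl group as the change that brought the read-out within range.

Compound 4 `Cc1ccc(-n2nncc2CN2C(=O)C3(C(C#N)=C(N)Oc4c3c3nc5ccccc5nc3c3ccccc43)c3ccccc32)cc1Cl` carries the change (3-chloro-4-methylphenyl in place of 3-sulfamoylphenyl on an aromatic nitrogen). Among the measured compounds shown here, no measured step reproduces this exact exchange; the two measured steps concern the arrival of the sulfamoyl group, and its removal is expected to undo them at least in part. Compound 4 is therefore expected to show a 3.5-fold higher number from compound 3 to compound 4 (0.55 log units; beyond the scatter), towards weaker inhibition. Compound 4 is estimated at 40000 nM, between 12000 nM and 150000 nM, with a fair chance that only a limit is reported.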

Compound 4, half-maximal inhibitory concentration: > 50000 nM
Compound 4 ended at the assay's limit (the forecaster's own chance of this, stated with the estimate: 55%); at least 1.2-fold (0.09 log units) between middle value and limit.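

With 3-chloro-4-methylphenyl in place of 3-sulfamoylphenyl on the aromatic nitrogen, this assay shows an at least 4.4-fold higher number from compound 3 to compound 4 (0.64 log units; beyond the scatter). This is a third aryl group without the sulfamoyl group to end at a limit rather than a number, leaving compound 3 alone within range: the limit of > 50000 nM in this assay, at which 3 of the 4 values shown sit.

The steps among compound 1, compound 2 and compound 4 cannot be read, since all three values are limits. On these data alone, whether a carboxylic acid or an amine could replace the sulfamoyl group and keep a readable value remains open, as does the effect of moving the sulfamoyl group to give 4-sulfamoylphenyl.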